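A few compounds are considered here, and "the series" means these few. Any claim that something is new, unique, unknown or untested is made for them only; others in the source may bear on it.

Measured in an ADME assay on BJ cells (Homo sapiens) for cytotoxicity, with a stated time of 72 h; a lower number here means that less compound is needed, a higher number that more compound is needed for the effect:

- Compound 1 `Cc1cc(NC(=O)Nc2ccc(C(C)(C)C)cc2)c2ccccc2n1`: 20000 nM
- Compound 2 `CC(=O)c1ccc(NC(=O)Nc2cc(C)nc3ccccc23)cc1`: 22000 nM
- Compound 3 `Cc1cc(NC(=O)Nc2ccccc2N)c2ccccc2n1`: > 25000 nM (a limit)

Compound 3 has no number of its own, and its > 25000 nM is a limit of this assay. Compound 4 `Cc1ccc(NC(=O)Nc2cc(C)nc3ccccc23)cc1` differs from it by 4-methylphenyl in place of 2-aminophenyl on an amide-type nitrogen, with 4-methylphenyl in place of 2-aminophenyl on an amide-type nitrogen. For the measured compounds named here, the only measured step, a 1.1-fold higher number from compound 1 to compound 2 (0.04 log units; within the scatter), exchanges acetyl for tert-butyl on an aromatic carbon and bears on this change only indirectly. That step suggests little sensitivity to such a swap, so compound 4 is expected to lie close to compound 2 at 22000 nM. The expected change is small, an at least 1.1-fold lower number from compound 3 to compound 4 (0.07 log units; that floor lies within the scatter), towards a lower number or none beyond the scatter. For compound 4 the estimate is 21000 nM, with an expected range of 11000 nM to 35000 nM.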

Compound 4, half-maximal effective concentration: > 25000 nM
Compound 4 ended at the assay's limit; the forecaster's own chance of this, stated with the estimate: 35%; at least 1.1-fold (0.07 log units) between middle value and limit.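

In this assay compound 4 gives > 25000 nM, which is a limit, so 4-methylphenyl on an amide-type nitrogen gives the same limit as 2-aminophenyl, and the step between them cannot be read. Methyl in place of acetyl gives an at least 1.1-fold higher number from compound 2 to compound 4 (0.05 log units; that floor lies within the scatter), and methyl in place of tert-butyl gives an at least 1.2-fold higher number from compound 1 to compound 4 (0.09 log units; that floor lies within the scatter), so neither floor shows a change beyond the scatter. This limit now recurs among the compounds: the limit of > 25000 nM in this assay, at which 2 of the 4 values shown sit.

From the compounds shown here alone, how far compound 3 and compound 4 truly lie from each other stays open. Also open, going by these compounds, is whether a carboxylic acid or a longer chain on that nitrogen would give a readable number.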